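The source may hold more compounds than are shown below. What is called first, only, known or untested is meant among the compounds shown, and "the series" means these compounds.

Compound 1 `CSc1ccc(CNc2nc(SC)nc3ncccc23)cc1` and compound 2 `COc1ccc(CNc2nc(SC)nc3ncccc23)cc1` share one core; compound 3 `COc1ccc(CNc2nc(SC)nc3ccccc23)cc1` and compound 4 `CSc1ccc(CNc2nc(SC)nc3ccccc23)cc1` share another, and the difference between the two cores is not broken down here. In a functional assay on CCRF-CEM cells (Homo sapiens) for cytotoxicity, read by MTT assay, with a stated time of 72 h (a higher number here means a weaker inhibitor of growth, a lower number a stronger inhibitor of growth), compound 1 gives 5350 nM. For compound 2 this assay reports only a limit, > 100000 nM. Compound 3 gives 93700 nM in this assay. The change methylsulfanyl in place of methoxy on an aromatic carbon made an at least 18-fold lower number from compound 2 to compound 1 (1.27 log units; beyond the scatter), and the full size of that step is left open by the limit of > 100000 nM in this assay, at which 1 of the 3 values shown sits. The same change, (methylsulfanyl in place of methoxy on an aromatic carbon), is made from compound 3 to compound 4. A step of comparable size is expected there because the earlier pair showed an at least 18-fold lower number from compound 2 to compound 1 (1.27 log units; beyond the scatter). Compound 4 is therefore expected to give about 6000 nM in this assay, the estimated step being a 16-fold lower number from compound 3 to compound 4 (1.19 log units; beyond the scatter), with the expected range running from 1500 nM to 30000 nM.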

Compound 4, concentration for 50% growth inhibition: > 100000 nM
Compound 4 was reported as a limit (the forecaster's own chance of this, stated with the estimate: 5%); middle value at least 16-fold (1.22 log units) away from the limit.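

Methylsulfanyl in place of methoxy on an aromatic carbon does not carry from one core to the other in this assay: the same change on two cores in this assay, an at least 18-fold lower number (1.27 log units; beyond the scatter) from compound 2 to compound 1 and an at least 1.0-fold higher number (0.02 log units; that floor lies within the scatter) from compound 3 to compound 4, at least 19-fold (1.29 log units) apart, beyond the scatter of two such steps

The new step is an at least 1.0-fold higher number from compound 3 to compound 4 (0.02 log units; that floor lies within the scatter), and its full size stays open, as compound 4 is reported only as a limit: the limit of > 100000 nM in this assay, at which 2 of the 4 values shown sit.

The gain seen on the core of compound 1 therefore cannot be assumed on the core of compound 3, but these two pairs do not show what in the cores separates them.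

Also open, as far as these compounds go, is whether an amine, a carboxylic acid or a longer chain at the same place would behave alike on both cores. Two pairs cannot show which core is the more typical for this change.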